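Benzyl purine pair: amino added to the core

This account rests on a few compounds, and the source may have more. Where it says the series, first, only, none or still open, it means among the compounds named here.

Measured compounds:
- compound 1, `ClCc1ccc(Cn2cnc3c(Cl)ncnc32)cc1`: in a functional assay on PC-3 cells (Homo sapiens) for cytotoxicity, read by sulforhodamine B assay, with a stated time of 48 h (on this read-out higher numbers stand for lower toxicity in this test and lower numbers for higher toxicity in this test), compound 1 gives > 100000 nM, which is a limit of the assay and not a number.
- compound 2, `ClCc1cccc(Cn2cnc3c(Cl)ncnc32)c1`: in this assay compound 2 gives 67600 nM.

Compound 2 thus holds the only number shown in this assay; the other value sits at the limit (the limit of > 100000 nM in this assay, at which 1 of the 2 values shown sits). Among the measured compounds shown here, no step between measured compounds is available, so the data set no size for any change.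

Compound 3, `Nc1nc(Cl)c2ncn(Cc3cccc(CCl)c3)c2n1`, has not yet been measured. It differs from compound 2 by amino in place of hydrogen on an aromatic carbon, between two ring nitrogen atoms of the core. For the measured compounds named here, with no measured step to lean on, the expectation is a step within the scatter, in no firm direction. Compound 3 is expected to give 60000 nM in this assay, with a range from 20000 nM to 200000 nM. The step this estimate implies, a 1.1-fold lower number from compound 2 to compound 3 (0.05 log units; within the scatter), is expected to be small.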

Compound 3, concentration lethal to 50% of the cells: 63100 nM
The estimate for compound 3 lay 1.1-fold (0.02 log units) below the measured number; measured number inside the range.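

Amino in place of hydrogen on an aromatic carbon, between two ring nitrogen atoms, is the first change in the series whose size can be read: in this assay it gives a 1.1-fold lower number from compound 2 to compound 3 (0.03 log units; within the scatter). At this position, then, hydrogen and amino give numbers within the scatter of each other, and this one step shows no effect of the change on the read-out. Compound 1 remains a limit and not a number, so it supplies no step: the limit of > 100000 nM in this assay, at which 1 of the 3 values shown sits.

Going by these compounds, whether a dimethylamino or methoxy group at the same position would also stay within the scatter remains open. One step also cannot tell whether amino would give a similarly small step on the structure of compound 1, whose value offers no number to compare.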